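This account rests on a few compounds, and the source may have more. Where it says the series, first, only, none or still open, it means among the compounds named here.

Measured compounds: compound 1 `O=C(Nc1ccc(Oc2ccnc3[nH]ccc23)cc1)c1cc(-c2ccc(C(F)(F)F)cc2)ncn1` with 6240 nM; compound 2 `O=C(Nc1ccc(Oc2ccnc3[nH]ccc23)c(F)c1)c1cc(-c2ccccc2)ncn1` with 4640 nM; compound 3 `O=C(Nc1ccc(Oc2ccnc3[nH]ccc23)c(F)c1)c1cc(-c2ccc(Cl)cc2)ncn1` with 26900 nM.

Compound 3 gives the highest of the three numbers in a functional assay on MCF7 cells (Homo sapiens) for cytotoxicity, read by MTT assay, with a stated time of 72 h; a lower number here means a stronger inhibitor, a higher number a weaker inhibitor. Within the data shown here, the nearest to it is compound 1, and the furthest is compound 2; the single one-place step among the measured compounds, a 5.8-fold higher number from compound 2 to compound 3 (0.76 log units; beyond the scatter), lies beyond the scatter, so compound 3 is the weakest of the three on this assay.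

Compound 4 `O=C(Nc1ccc(Oc2ccnc3[nH]ccc23)c(F)c1)c1cc(-c2ccc(C(F)(F)F)cc2)ncn1` is reached from compound 3 by trifluoromethyl in place of chloro on an aromatic carbon, on an aromatic carbon of a six-membered aromatic ring of carbon only, para to a large group. Among the measured compounds shown here, no measured step changes chloro to trifluoromethyl directly. What bears on it is compound 1, which carries the same trifluoromethyl group on the shared core but lacks the fluorine of compounds 2 and 3. In this assay compound 1 gives 6240 nM, a lower number than compound 3. On that basis compound 4 is expected to land near compound 1, which means a step of a 3.4-fold lower number from compound 3 to compound 4 (0.53 log units; beyond the scatter) toward a lower number. The estimate for compound 4 in this assay is 8000 nM, with a range from 3000 nM to 25000 nM.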

Compound 4, half-maximal inhibitory concentration: 2840 nM
Estimate against measurement, compound 4: 2.8-fold (0.45 log units) above, and the stated range ends above it.
By their numbers in this assay, from the lowest: compounds 4, 2 and 1 (each within the scatter of the next, the first and the last beyond it); then compound 3.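

Chloro and trifluoromethyl are not interchangeable at this place, para to a large group: in this assay the exchange gives a 9.5-fold lower number from compound 3 to compound 4 (0.98 log units; beyond the scatter), so the weak result of compound 3 belongs to its chloro group and not to the substituted ring position as such. Trifluoromethyl and hydrogen cannot be told apart at this place, with a 1.6-fold lower number from compound 2 to compound 4 (0.21 log units; within the scatter), so the rise in the number seen with chloro is not shared by trifluoromethyl. With trifluoromethyl held constant, the added fluorine on the shared core gives a modest change, a 2.2-fold lower number from compound 1 to compound 4 (0.34 log units; beyond the scatter), which is the first reading of fluoro in place of hydrogen among these compounds.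

The compounds shown leave open whether a methoxy group or an amine at this place would track chloro or trifluoromethyl, and whether the fluoro step would have the same size and direction with hydrogen or chloro on the outer ring. Nothing at hand explains why chloro stands apart from the other two groups in this series.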